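A few compounds are considered here, and "the series" means these few. Any claim that something is new, unique, unknown or untested is made for them only; others in the source may bear on it.

Measured in a functional assay on MDA-MB-231 cells (Homo sapiens) for antiproliferative activity, read by MTT assay, with a stated time of 48 h; on this read-out higher numbers stand for weaker inhibition and lower numbers for stronger inhibition:
compound 1, `C/C(=C\CC/C(C)=C/CC[C@@H]1[C@@]2(C)CCC(=O)C(C)(C)[C@H]2CC[C@@]1(C)O)CC/C=C(\C)C(=O)OCc1cn(-c2ccccc2Cl)nn1`: > 150000 nM, a limit of the assay.
compound 2, `C/C(=C\CC/C(C)=C/CC[C@@H]1[C@@]2(C)CCC(=O)C(C)(C)[C@H]2CC[C@@]1(C)O)CC/C=C(\C)C(=O)OCc1cn(-c2ccccc2)nn1`: > 150000 nM, a limit of the assay.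
compound 3, `C/C(=C\CC/C(C)=C/CC[C@@H]1[C@@]2(C)CCC(=O)C(C)(C)[C@H]2CC[C@@]1(C)O)CC/C=C(\C)C(=O)OCc1cn(C[C@@H]2O[C@H](n3ccc(=O)[nH]c3=O)C[C@H]2O)nn1`: 26300 nM.

Compound 2 stands at a limit of this assay, so no number is known for it. Two of the three values shown sit there, as the limit of > 150000 nM in this assay, at which 2 of the 3 values shown sit, records. Within the data shown here, compound 3, with the nucleoside-bearing triazole in place of the aryl triazole, is the only member with a measured number.

The compound not yet measured is compound 4, `C/C(=C\CC/C(C)=C/CC[C@@H]1[C@@]2(C)CCC(=O)C(C)(C)[C@H]2CC[C@@]1(C)O)CC/C=C(\C)C(=O)OCc1cn(-c2ccccc2Br)nn1`. Against compound 2 the change is bromo in place of hydrogen on an aromatic carbon.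

Among the measured compounds shown here, the one measured step of a related kind is a step that the two limits leave unreadable from compound 1 to compound 2, the reverse sort of change, a halogen leaving rather than entering, and its size cannot be read since both its ends sit at the limit. Nothing measured therefore gives a direction or a size for the present step, and compound 2 itself offers only a limit to start from.

Compound 4 is expected to remain at or near the limit, estimated at 200000 nM, in the range 80000 nM to 600000 nM. The expected step is a step that the limit leaves unreadable from compound 2 to compound 4, not distinguishable from no change.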

Compound 4, half-maximal inhibitory concentration: > 150000 nM
Compound 4: a limit, no number (the forecaster's own chance of this, stated with the estimate: 80%); the middle value lies beyond the limit too.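

Among these compounds, compound 4 gives > 150000 nM, a limit of the assay and not a number, so no step among compound 1, compound 2 and compound 4 can be read. From the compounds shown here alone, whether bromo, chloro or hydrogen on that aromatic carbon makes any difference remains open.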